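This account rests on a few compounds, and the source may have more. Where it says the series, first, only, none or still open, it means among the compounds named here.

Measured compounds:

Compound 1 `O=C1C(=O)N(CN2CCCCC2)c2cccc(Cl)c21` gives 26500 nM in a functional assay on MDA-MB-231 cells (Homo sapiens) for cytotoxicity, read by sulforhodamine B assay, with a stated time of 48 h; a lower number here means a stronger inhibitor of growth, a higher number a weaker inhibitor of growth.
Compound 2 `CCN(CC)CN1C(=O)C(=O)c2c(Cl)cccc21` gives 44500 nM in this assay.

Going by the values given here, on these two numbers compound 2 has the higher one, but the only step recorded, a 1.7-fold higher number from compound 1 to compound 2 (0.23 log units; within the scatter), lies within the scatter, so the two compounds cannot be told apart on this assay. Compound 3 `CN(C)CN1C(=O)C(=O)c2c(Cl)cccc21` has not yet been measured. It differs from compound 2 by dimethylamino in place of diethylamino on a saturated chain carbon bound to an amide-type nitrogen in a ring. Among the compounds with values here, the one measured step that bears on this change is a 1.7-fold higher number from compound 1 to compound 2 (0.23 log units; within the scatter), an exchange of one amine for another at the same place that left the number essentially unchanged. Within the data shown here, there is no measured pair in which the amine was made smaller, so the size of the dimethylamino change rests only on this analogy. On that basis compound 3 is expected to stay close to compound 2, with a step of a 1.1-fold higher number from compound 2 to compound 3 (0.05 log units; within the scatter) that does not go beyond the scatter. The estimate for compound 3 in this assay is therefore 50000 nM, with a range from 20000 nM to 120000 nM.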

Compound 3, concentration for 50% growth inhibition: 138000 nM
Estimate against measurement, compound 3: 2.8-fold (0.44 log units) below; the measured number lies above the stated range.
By their numbers in this assay, from the lowest: compounds 1 and 2 (each within the scatter of the next); then compound 3.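

In this assay, the amine on a saturated chain carbon bound to an amide-type nitrogen in a ring proves not to be freely exchangeable: replacing diethylamino, with 5 heavy atoms, by dimethylamino, with 3, gives a 3.1-fold higher number from compound 2 to compound 3 (0.49 log units; beyond the scatter). Exchanging piperidin-1-yl for dimethylamino at the same place gives a 5.2-fold higher number from compound 1 to compound 3 (0.72 log units; beyond the scatter), so among these three compounds only dimethylamino stands apart, while piperidin-1-yl and diethylamino remain indistinguishable, and all three numbers lie in the same high range, with the change moving the number only modestly. Nothing shown here accounts for the loss in growth inhibition on going to dimethylamino.

With only three amines in hand, the compounds leave open whether the number would keep falling with a larger amine such as dipropylamino, or whether it would hold level, as it does from piperidin-1-yl to diethylamino. They also leave open how other ring amines, such as pyrrolidine or morpholine, would behave at this place, and whether any amine here can bring the number far below those of compound 1 and compound 2.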